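The compounds below may be only part of what the source reports. "The series", "measured", "known", "first", "only" and "open" are said of these compounds alone.

Compound 2 `Cc1cc(C(=O)N2CCCCc3ccccc32)ccc1CNC(=O)NCC(=O)N(C)C` stands at the lower end of the two numbers recorded so far: in a functional assay on HEK293 cells for agonist activity at Vasopressin V2 receptor (Homo sapiens), read by a luciferase reporter and cAMP accumulation (on this read-out higher numbers stand for an effect only at larger amounts of compound and lower numbers for an effect already at smaller amounts), compound 2 gives 58 nM. For the measured compounds named here, its only measured neighbour, compound 1 `Cc1cc(C(=O)N2CCCCc3ccccc32)ccc1CNC(=O)NCC(=O)OC(C)C`, gives 140 nM in this assay, and the single recorded step between them, a 2.4-fold lower number from compound 1 to compound 2 (0.38 log units; beyond the scatter), came from putting dimethylamino in place of isopropoxy on the carbonyl carbon.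

Compound 3 `Cc1cc(C(=O)N2CCCCc3ccccc32)ccc1CNC(=O)NCC(=O)N1CCCC1` differs from compound 2 by pyrrolidin-1-yl in place of dimethylamino on a carbonyl carbon. Going by the values given here, the one measured step does bear on it, since it concerns the same carbonyl carbon, but it was modest, and the present change is smaller in kind: a dimethylamino group is traded for a pyrrolidin-1-yl group of the same kind, closing two carbons into a five-membered ring. On that basis the step of a 1.2-fold lower number from compound 2 to compound 3 (0.06 log units; within the scatter) from compound 2 to compound 3 is expected to stay within the scatter in this assay. Compound 3 is therefore estimated at 50 nM, with a range from 20 nM to 130 nM.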

Compound 3, half-maximal effective concentration: 100 nM
For compound 3 the middle estimate is 2.0-fold (0.30 log units) below the measured one; measured number inside the range.
By their numbers in this assay, from the lowest: compounds 2, 3 and 1 (each within the scatter of the next, the first and the last beyond it).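

On this carbonyl carbon, closing dimethylamino into pyrrolidin-1-yl gives a 1.7-fold higher number from compound 2 to compound 3 (0.24 log units; within the scatter) in this assay, so the read-out does not separate these two groups. Pyrrolidin-1-yl in place of isopropoxy gives a 1.4-fold lower number from compound 1 to compound 3 (0.15 log units; within the scatter), so compound 3 cannot be separated from either neighbour. The only step here that clears the scatter is still a 2.4-fold lower number from compound 1 to compound 2 (0.38 log units; beyond the scatter), which means this position has so far shown only a modest range of numbers across the three groups. Nothing available accounts for these numbers.

From the compounds shown here alone, it remains open whether a six-membered ring such as piperidin-1-yl or morpholin-4-yl on the same carbonyl carbon would stay within this range. The same question applies to a plain amino group or a carboxylic acid in this place.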